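Trading an aryl ring for methyl on the pyrazoline core

The compounds below may be only part of what the source reports. "The series", "measured", "known", "first", "only" and "open" are said of these compounds alone.

Compound 2 `O=C(Nc1ccc(F)cc1)N1N=C(c2ccccc2)CC1c1ccc(F)cc1` gives the lowest number of the three measured compounds in an assay on HEK293 cells for inhibition of Voltage-dependent T-type calcium channel subunit alpha-1H (Homo sapiens), read by FLIPR and calcium flux, with a stated time of 3 min (a lower number here means a stronger inhibitor, a higher number a weaker inhibitor), with 25 nM. Compound 1 `O=C(Nc1ccncc1)N1N=C(c2ccccc2)CC1c1ccc(F)cc1` gives 202 nM in this assay, and the change an 8.1-fold lower number from compound 1 to compound 2 (0.91 log units; beyond the scatter) separates the two. Compound 3 `O=C(Nc1ccc(F)cc1)N1N=C(c2cc[n+]([O-])cc2)CC1c1ccc(F)cc1` gives 110 nM, and the change a 4.4-fold higher number from compound 2 to compound 3 (0.64 log units; beyond the scatter) separates it from compound 2. Both steps lie beyond the scatter, so compound 2 is the strongest inhibitor among the three.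

Compound 4 `CC1CC(c2ccccc2)=NN1C(=O)Nc1ccc(F)cc1` differs from compound 2 by methyl in place of 4-fluorophenyl on a saturated ring carbon. Neither measured step touches this saturated ring carbon: one alters the aryl group on the amide-type nitrogen, the other the ring on the carbon with a double bond to nitrogen, and both were modest in size. There is thus no direct guide, but the change removes an entire aromatic ring rather than swapping one ring for another, so a step towards a higher number, beyond the scatter, is expected. For compound 4 the expected step is a 60-fold higher number from compound 2 to compound 4 (1.78 log units; beyond the scatter), giving an estimated 1500 nM in this assay, within a range from 300 nM to 8000 nM.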

Compound 4, half-maximal inhibitory concentration: 410 nM
The estimate for compound 4 lay 3.7-fold (0.56 log units) above the measured number; low and high end bracket the measured number.
By their numbers in this assay, from the lowest: compound 2; then compounds 3 and 1 (each within the scatter of the next); then compound 4.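

Among these compounds, every earlier compound carried 4-fluorophenyl on this saturated ring carbon, so this pair gives the first reading of what that group contributes in this assay. Methyl in its place produces a 16-fold higher number from compound 2 to compound 4 (1.21 log units; beyond the scatter) and is the only step so far rated large, which marks this position as sensitive to change. Even so, inhibition is not lost, as compound 4 still gives 410 nM with no ring at this position, and no measurement shown explains the rise.

Going by these compounds, only 4-fluorophenyl and methyl appear here, so it remains open whether the difference follows from the whole ring or from its fluorine, which plain phenyl would help to separate. An ethyl or cyclohexyl group would show whether a larger group without an aromatic ring recovers any of the lost strength.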